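This account rests on a few compounds, and the source may have more. Where it says the series, first, only, none or still open, it means among the compounds named here.

Working notes on the series, all read in a functional assay on DU-145 cells (Homo sapiens) for inhibition, read by trypan blue exclusion, with a stated time of 96 h; a lower number here means a stronger inhibitor of growth, a higher number a weaker inhibitor of growth. Of the compounds shown here, two carry numbers so far. Compound 1 `CSc1ccc(/C=C(/Sc2ccc(C)cc2)C(=O)c2ccc(Br)cc2)cc1` gives 50000 nM. Compound 2 `CSc1ccc(/C=C(/SCc2ccc(C)cc2)C(=O)c2ccc(Cl)cc2)cc1` gives 25000 nM. These two values lie within the usual scatter of each other, so the pair cannot be ranked. Among the measured compounds shown here, the two compounds also differ in more than one place, and the series therefore offers no measured single-change step.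

Compound 3 `CSc1ccc(/C=C(/SCc2ccc(C)cc2)C(=O)c2ccc(Br)cc2)cc1` has not yet been measured. It comes from compound 2 by one change, bromo in place of chloro on an aromatic carbon, para to a large group. For the measured compounds named here, no measured pair covers this change, so no shift beyond the scatter is expected in this assay, and neither direction is favoured. The expectation therefore stays with compound 2 at 25000 nM. The expected size of the move is no change at the digits printed from compound 2 to compound 3 (within the scatter). For compound 3 the estimated value is 25000 nM, with an expected range of 12000 nM to 50000 nM.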

Compound 3, concentration for 50% growth inhibition: > 100000 nM
Compound 3: only a limit was reported; the forecaster's own chance of this, stated with the estimate: 10%; middle value at least 4.0-fold (0.60 log units) away from the limit.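

Compound 3 carries only a limit in this assay, not a number, and it is the one limit among the compounds shown: the limit of > 100000 nM in this assay, at which 1 of the 3 values shown sits.

Bromo in place of chloro on an aromatic carbon, para to a large group, gives the first measured single-change step of the series, an at least 4.0-fold higher number from compound 2 to compound 3 (0.60 log units; beyond the scatter), so at this position the two halogens are not interchangeable, and the chloro compound is the stronger inhibitor of growth by a margin whose full size the limit hides. The second step, 4-methylbenzyl in place of 4-methylphenyl on a sulfur, reads as an at least 2.0-fold higher number from compound 1 to compound 3 (0.30 log units; that floor lies within the scatter), and as its floor lies within the scatter, it fixes no order for that change.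

It remains open whether the chloro-to-bromo step reads the same way with 4-methylphenyl on the sulfur, a setting in which the compounds shown offer only the bromo member, compound 1. Also open, going by these compounds, is how fluoro, a methoxy group or an amine would read on the same aromatic carbon, and whether any of them would carry the series past the chloro compound.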